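A Neopentyl Variant of a Poorly Soluble Compound

The compounds below may be only part of what the source reports. "The series", "measured", "known", "first", "only" and "open" are said of these compounds alone.

Compound 2 `CC(=O)Nc1cc(-c2ccc(N(C)C(=O)c3c(F)cccc3Cl)c(N3CC4CC4C3)c2)n(C(C)C2CC2)n1` is the less soluble of the two measured compounds: in a physicochemical assay for solubility, measured as kinetic solubility (a lower number here means a less soluble compound, a higher number a more soluble compound), compound 2 gives 0.5 ug/mL, whereas compound 1 `CC(=O)Nc1cc(-c2cnc(N(C)C(=O)c3c(F)cccc3Cl)c(N3CC4CC4C3)c2)n(C(C)C)n1` gives 48 ug/mL, a gap well beyond the usual scatter. Compound 3 `CC(=O)Nc1cc(-c2ccc(N(C)C(=O)c3c(F)cccc3Cl)c(N3CC4CC4C3)c2)n(CC(C)(C)C)n1` differs from compound 2 in one place: neopentyl in place of 1-cyclopropylethyl on an aromatic nitrogen. Going by the values given here, no measured pair shows this particular swap, so the expectation rests only on the two values above and the small size of the change. The step of a 1.2-fold higher number from compound 2 to compound 3 (0.08 log units; within the scatter) is expected to fall within the scatter. Compound 3 is therefore estimated at 0.6 ug/mL in this assay, between 0.2 ug/mL and 2 ug/mL.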

Compound 3, solubility: 0.8 ug/mL
The estimate for compound 3 lay 1.3-fold (0.12 log units) below the measured number; the measured number falls inside the stated range.
By their numbers in this assay, from the lowest: compounds 2 and 3 (each within the scatter of the next); then compound 1.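

In this assay, neopentyl in place of 1-cyclopropylethyl on this aromatic nitrogen gives a 1.6-fold higher number from compound 2 to compound 3 (0.20 log units; within the scatter). At this position, then, a group with a three-membered ring and a group with no ring, each of 5 carbon atoms, cannot be told apart by this read-out. Nothing available here offers an explanation for this result. Still open, going by these compounds, is how a group holding an amine or a hydroxyl on this same nitrogen would read. On these data alone, it is also open whether a longer carbon chain there would stay within the scatter.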